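Removing one methyl group from compound 1

This account rests on a few compounds, and the source may have more. Where it says the series, first, only, none or still open, it means among the compounds named here.

Values in a functional assay on A549 cells (Homo sapiens) for inhibition, read by sulforhodamine B assay, with a stated time of 48 h (a lower number here means a stronger inhibitor, a higher number a weaker inhibitor), for the measured compounds:
- compound 1 `COc1ccc(C(O)(Cc2ccc(C)cc2)c2cccc3ccccc23)c(OC)c1OC`: 18700 nM
- compound 2 `COc1ccc(/C(=C\c2ccc(F)cc2)c2cccc3ccccc23)c(OC)c1OC`: > 20000 nM (a limit of the assay, not a number)
- compound 3 `COc1ccc(C(c2ccccc2O)c2cccc3ccccc23)c(OC)c1OC`: 13600 nM

Only two of these results are true numbers. Compound 1 at 18700 nM and compound 3 at 13600 nM lie within the usual scatter of each other, so neither can be ranked above the other.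

Compound 4 `COc1ccc(C(O)(Cc2ccccc2)c2cccc3ccccc23)c(OC)c1OC` keeps the core of compound 1 and differs from it in one place. It has hydrogen in place of methyl on an aromatic carbon, para to a large group, so that 4-methylbenzyl becomes benzyl (hydrogen in place of methyl on an aromatic carbon).

For the measured compounds named here, no measured pair here tests this change, so the expectation starts from compound 1 at 18700 nM and assumes no shift beyond the scatter. The estimated step of a 1.2-fold lower number from compound 1 to compound 4 (0.07 log units; within the scatter) is expected to stay within that scatter, with no clear direction. In this assay the estimated value for compound 4 is 16000 nM, with an expected range from 9000 nM to 26000 nM.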

Compound 4, half-maximal inhibitory concentration: > 20000 nM
Compound 4: a limit, no number (the forecaster's own chance of this, stated with the estimate: 25%); at least 1.2-fold (0.09 log units) between middle value and limit.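

Compound 4 sits at a limit of the assay, not at a number, so this first pair to test hydrogen in place of methyl on this aromatic carbon in this assay gives only a floor: an at least 1.0-fold higher number from compound 1 to compound 4 (0.02 log units; that floor lies within the scatter). Going from 4-methylbenzyl to benzyl therefore shows no move to a lower number, which means the methyl group cannot be dropped here for any gain that this read-out can detect. Whether compound 4 truly differs from compound 1 cannot be told, and such a ceiling is common in this small set: the limit of > 20000 nM in this assay, at which 2 of the 4 values shown sit.

The compounds shown leave open whether any group at this position could give a clearly lower number than compound 1. An amine or a carboxylic acid in place of the methyl group lies outside what they can say.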